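From 4-methylphenyl to 3-chlorophenyl on compound 3

The compounds below may be only part of what the source reports. "The series", "measured", "known", "first", "only" and "open" are said of these compounds alone.

Of the compounds shown here, three have so far been measured in a functional assay on PANC-1 cells (Homo sapiens) for antiproliferative activity, read by sulforhodamine B assay, with a stated time of 48 h; a lower number here means a stronger inhibitor of growth, a higher number a weaker inhibitor of growth. Compound 1 `Cc1ccc(-c2nnc(C3=C(Cl)c4ccccc4CCC3)o2)cc1` gives 6810 nM, compound 2 `O=[N+]([O-])c1ccc(-c2nnc(C3=C(Cl)c4ccccc4CCC3)o2)cc1` gives 3980 nM, and compound 3 `Cc1ccc(-c2nnc(C3=C(Cl)c4cc(C)c(C)cc4CCC3)o2)cc1` gives 3880 nM. The value of compound 3 lies within the scatter of the other two values, so these numbers do not rank the three compounds.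

Compound 4 `Cc1cc2c(cc1C)C(Cl)=C(c1nnc(-c3cccc(Cl)c3)o1)CCC2` keeps the core of compound 3 and differs in one place: 3-chlorophenyl in place of 4-methylphenyl on an aromatic carbon. This puts 3-chlorophenyl in place of 4-methylphenyl on an aromatic carbon of the five-membered aromatic ring with 2 nitrogen and 1 oxygen.

Going by the values given here, only one measured step bears on this change, as it also alters the 4-methylphenyl group. That step, with nitro in place of methyl on an aromatic carbon, is a 1.7-fold lower number from compound 1 to compound 2 (0.23 log units; within the scatter). Among the compounds with values here, no measured compound carries the 3-chlorophenyl group, so this single step is a limited guide. On that evidence, no step beyond the scatter is expected in this assay, and no direction can be favoured. The expected change is a 1.1-fold lower number from compound 3 to compound 4 (0.04 log units; within the scatter). For compound 4, the estimated value is 3500 nM, with an expected range from 1500 nM to 8000 nM.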

Compound 4, concentration for 50% growth inhibition: 4570 nM
Compound 4: the middle estimate sits 1.3-fold (0.12 log units) below what was measured; the range from low to high includes it.
By their numbers in this assay, from the lowest: compounds 3, 2, 4 and 1 (each within the scatter of the next).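

In this assay, replacing the whole 4-methylphenyl group with 3-chlorophenyl on the aromatic carbon next to the ring oxygen gives a step within the scatter (a 1.2-fold higher number from compound 3 to compound 4 (0.07 log units; within the scatter)). Going by these compounds alone, the earlier step at this place (a 1.7-fold lower number from compound 1 to compound 2 (0.23 log units; within the scatter)) exchanged only methyl for nitro on the group and was read on the core of compound 1, so this is the first step to show a full exchange of the group, and the first at this place on the core of compound 3. Neither step separates the compounds it joins, so the numbers show no sensitivity to these changes at this place, and nothing among the data shown accounts for that result.

The compounds shown leave open whether a group of a different kind at this place, such as an aminophenyl group, a carboxylic acid or a longer chain, would give a step beyond the scatter. They also leave open whether 3-chlorophenyl would give a similar step on the core of compound 1, which would show if the reading on the core of compound 3 carries over.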